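Aryl exchange on compound 1: expected growth inhibition

The source may report more compounds than this note shows. Statements on the series, on what has been measured and on what is new or still open speak of the compounds shown alone.

Going by the values given here, in a functional assay on 786-0 cells (Homo sapiens) for inhibition (on this read-out higher numbers stand for weaker inhibition of growth and lower numbers for stronger inhibition of growth), three compounds with closely related structures have numbers so far. Compound 1 (`COc1cc(/C=C/C(=O)c2cccc(-n3cc(-c4ccc(Cl)cc4)[nH]c3=O)c2)cc(OC)c1OC`) gives 2140 nM, compound 2 (`O=C(/C=C/c1cccc(O)c1)c1cccc(-n2cc(-c3ccccc3)[nH]c2=O)c1`) gives 2980 nM and compound 3 (`O=C(/C=C/c1cccc(O)c1)c1cccc(-n2cc(-c3ccc(Cl)cc3)[nH]c2=O)c1`) gives 1570 nM. Compound 1 lies within the scatter of both others, so these numbers set no ranking among the three.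

Compound 4 (`COc1cc(/C=C/C(=O)c2cccc(-n3cc(-c4cc(OC)c(OC)c(OC)c4)[nH]c3=O)c2)cc(OC)c1OC`) is the next case. The change is 3,4,5-trimethoxyphenyl in place of 4-chlorophenyl on an aromatic carbon, on an aromatic carbon of a five-membered aromatic ring with 2 nitrogen.

Among the compounds with values here, only one measured step bears on this group: a 1.9-fold lower number from compound 2 to compound 3 (0.28 log units; within the scatter), with chloro in place of hydrogen on an aromatic carbon. That step lies within the scatter. Within the data shown here, it is a much smaller exchange than the one in compound 4, and no measured compound carries 3,4,5-trimethoxyphenyl at this place. The data therefore give no direction for the change, and the range has to stay wide.

Among the measured compounds shown here, with the step to compound 3 at a 1.9-fold lower number from compound 2 to compound 3 (0.28 log units; within the scatter) as the only guide, nothing beyond the scatter is expected in this assay. The estimated step is a 1.2-fold higher number from compound 1 to compound 4 (0.07 log units; within the scatter). Compound 4 is estimated at 2500 nM, with an expected range of 800 nM to 7500 nM.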

Compound 4, concentration for 50% growth inhibition: 1590 nM
Beside the measured number, compound 4's estimate is 1.6-fold (0.20 log units) above it; low and high end bracket the measured number.
By their numbers in this assay, from the lowest: compounds 3, 4, 1 and 2 (each within the scatter of the next).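

In this assay, going by these compounds alone, the step of a 1.3-fold lower number from compound 1 to compound 4 (0.13 log units; within the scatter) is the first reading at this place in which one whole aryl group replaces another, whereas the earlier step only put chloro in place of hydrogen on the phenyl ring. It shows that 3,4,5-trimethoxyphenyl, with 12 heavy atoms and 3 hydrogen-bond acceptors, can enter in place of 4-chlorophenyl, with 7 heavy atoms and 0 hydrogen-bond acceptors, without moving the number beyond the scatter, so on the background of compound 1 this position accepts a clearly larger aryl group with no measurable loss of growth inhibition. No measurement at hand explains why the number stays within the scatter across this exchange.

Within the data shown here, the two aryl groups are the only large groups compared at this place, so it remains open whether a group of another kind, such as an amine, a carboxylic acid or a longer alkyl chain, would also leave the number within the scatter. On these data alone, it is also open whether 3,4,5-trimethoxyphenyl in place of 4-chlorophenyl would give a similar result on the background of compound 3.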